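From Tetrazole to Dimethylamide on the Ether Chain

This account rests on a few compounds, and the source may have more. Where it says the series, first, only, none or still open, it means among the compounds named here.

Compound 2 `CCc1cc(C(C)=O)c(O)cc1OCCCC(C)(C)c1nnn[nH]1` holds the higher of the two numbers measured in an assay on isolated protein for binding affinity to leukotriene B4 receptor 1 (Homo sapiens), tested at 1 uM; a higher number here means more inhibition at the concentration tested (going by the name of the read-out), a lower number less inhibition: compound 2 gives 76%, while compound 1 `CCCCc1cc(C(C)=O)c(O)cc1OCCCCC#N` gives 13%, a gap beyond the usual scatter. Compound 3 `CCc1cc(C(C)=O)c(O)cc1OCCCCCCC(=O)N(C)C` has not yet been measured. The change from compound 2 is 3-(dimethylcarbamoyl)propyl in place of 1-(1H-tetrazol-5-yl)-1-methylethyl on a saturated chain carbon, three bonds along the chain from an oxygen on an aromatic ring. Going by the values given here, no step between two measured compounds matches this change, so the expectation rests on the two numbers alone. Compound 3 is expected to lose ground, the step of a number 51 percentage points lower from compound 2 to compound 3 (beyond the scatter) in this assay being estimated as a clear fall. Compound 3 is estimated at 25%, within a range from 5% to 50%.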

Compound 3, a percentage reported as inhibition, at one concentration (the size of the read-out at that concentration, not a potency): 61%
For compound 3 the middle estimate is 36 percentage points below the measured one, and the stated range ends below it.
By their numbers in this assay, from the lowest: compound 1; then compound 3; then compound 2.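

In this assay, 3-(dimethylcarbamoyl)propyl in place of 1-(1H-tetrazol-5-yl)-1-methylethyl at this saturated chain carbon gives a modest fall, a number 15 percentage points lower from compound 2 to compound 3 (beyond the scatter), so the read-out does not depend on the tetrazole ring here. With no ring and no hydrogen-bond donor in the entering group, compound 3 still gives 61%. No measurement available here accounts for the size of this step. From the compounds shown here alone, whether a carboxylic acid on the same chain would do as well remains open. So does how a shorter chain carrying the dimethylamide would behave.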